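Replacing cyano with 4-methylpiperazin-1-yl in the series

The source may report more compounds than this note shows. Statements on the series, on what has been measured and on what is new or still open speak of the compounds shown alone.

In a functional assay on MDA-MB-436 cells (Homo sapiens) for antiproliferative activity, read by MTT assay, with a stated time of 48 h (on this read-out higher numbers stand for weaker inhibition and lower numbers for stronger inhibition), compound 2 (`C=CS(=O)(=O)N1CCN(c2nc(OC[C@H]3CCCN3C)nc3sc(-c4ccc(C#N)cc4)cc23)CC1`) gives the lower of the two numbers at 2290 nM against compound 1 (`C=CS(=O)(=O)N1CCN(c2ncnc3sc(-c4ccc(N5CCN(C)CC5)cc4)cc23)CC1`) at 8760 nM and this gap lies beyond the scatter. Compound 3 (`C=CS(=O)(=O)N1CCN(c2nc(OC[C@H]3CCCN3C)nc3sc(-c4ccc(N5CCN(C)CC5)cc4)cc23)CC1`) departs from compound 2 in one place: 4-methylpiperazin-1-yl in place of cyano on an aromatic carbon. For the measured compounds named here, no measured step isolates this change. Compound 1 at 8760 nM also carries 4-methylpiperazin-1-yl and points towards weaker inhibition. The expected move in this assay is small and upward, with a 1.2-fold higher number from compound 2 to compound 3 (0.09 log units; within the scatter) estimated to stay within the scatter. For compound 3 the expected value is 2800 nM (estimated range 900 nM to 7500 nM).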

Compound 3, half-maximal inhibitory concentration: 540 nM
The estimate for compound 3 lay 5.2-fold (0.71 log units) above the measured number; the measured number lies below the stated range.
By their numbers in this assay, from the lowest: compound 3; then compound 2; then compound 1.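

In this assay, for the compounds shown here, 4-methylpiperazin-1-yl in place of cyano gives a 4.2-fold lower number from compound 2 to compound 3 (0.63 log units; beyond the scatter) and so points towards stronger inhibition, a move the earlier compounds could not isolate. With 4-methylpiperazin-1-yl held fixed, (1-methylpyrrolidin-2-yl)methoxy in place of hydrogen gives a 16-fold lower number from compound 1 to compound 3 (1.21 log units; beyond the scatter) and is the larger of the two steps. Nothing available explains either step.

Open, on these data alone, is whether morpholin-4-yl or a primary amine on this aromatic carbon would match 4-methylpiperazin-1-yl. Also open, as far as these compounds go, is whether the change from cyano holds without (1-methylpyrrolidin-2-yl)methoxy.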